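Amino Group Added to a Quinolinone Amide

The compounds below may be only part of what the source reports. "The series", "measured", "known", "first", "only" and "open" are said of these compounds alone.

Of the compounds shown here, two have been tested so far in a functional assay on KYSE-70 cells for antiproliferative activity against KYSE-70 cell line (Homo sapiens), read by MTT assay, with a stated time of 72 h; on this read-out higher numbers stand for weaker inhibition and lower numbers for stronger inhibition. Compound 1, `O=C(c1ccnc2cc(Br)ccc12)N1CCCCC1`, gives only an assay limit there: compound 1 reads > 20000 nM, a limit rather than a number. Compound 2, `O=C(Nc1cccc(F)c1)c1cc(=O)[nH]c2cc(-c3ccccc3)ccc12`, likewise gives only a limit: compound 2 reads > 20000 nM in this assay. Both values therefore sit at the same place, (the limit of > 20000 nM in this assay, at which 2 of the 2 values shown sit), and neither compound shows a measurable inhibition of this cell line at the concentrations covered.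

The next compound, compound 3, `Nc1ccc(-c2ccc3c(C(=O)Nc4cccc(F)c4)cc(=O)[nH]c3c2)cc1`, differs from compound 2 in one place: amino in place of hydrogen on an aromatic carbon. Cut one bond further out, the change reads phenyl to 4-aminophenyl.

For the measured compounds named here, no measured step exists between any two compounds here, so there is nothing to lean on for the size of this change. A single amino group can shift potency in either direction, but with compound 2 at a limit only a gain would become visible. The expectation for compound 3 is a modest move toward stronger inhibition, an at least 1.6-fold lower number from compound 2 to compound 3 (0.22 log units; that floor lies within the scatter), with a fair chance that this assay again reports only a limit. Compound 3 is estimated at 12000 nM, within a range from 1500 nM to 60000 nM.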

Compound 3, half-maximal inhibitory concentration: > 20000 nM
Compound 3: a limit, no number; the forecaster's own chance of this, stated with the estimate: 50%; at least 1.6-fold (0.22 log units) between middle value and limit.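

Compound 2 and compound 3 both give only a limit in this assay, so no step can be read for the change from phenyl to 4-aminophenyl: the limit of > 20000 nM in this assay, at which 3 of the 3 values shown sit. The compounds shown leave open how far the amino group shifts inhibition of this cell line, and which structural change would yield a measurable number.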